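Working notes: the step to compound 4

The compounds below may be only part of what the source reports. "The series", "measured", "known", "first", "only" and "open" are said of these compounds alone.

In a functional assay on DU-145 cells (Homo sapiens) for antiproliferative activity, read by propidium iodide staining, with a stated time of 96 h (a higher number here means a weaker inhibitor, a lower number a stronger inhibitor), compound 1 `CC(O)(COc1ccc(S(F)(F)(F)(F)F)cc1)C(=O)Nc1cccc(S(F)(F)(F)(F)F)c1` gives 12800 nM, compound 2 `CC(O)(COc1cccc(C(F)(F)F)c1)C(=O)Nc1cccc(S(F)(F)(F)(F)F)c1` gives 31700 nM and compound 3 `CC(O)(COc1ccccc1C(F)(F)F)C(=O)Nc1cccc(S(F)(F)(F)(F)F)c1` gives 52200 nM. Compound 3 cannot be separated from compound 2 on these numbers, while compound 1 gives a lower number than compound 3 by more than the scatter.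

The next analogue, compound 4 `CC(O)(COc1ccc(C#N)cc1)C(=O)Nc1cccc(S(F)(F)(F)(F)F)c1`, carries 4-cyanophenyl in place of 2-(trifluoromethyl)phenyl on an oxygen on a saturated carbon.

Within the data shown here, only one measured step changes this same place between two close analogues: a 1.6-fold higher number from compound 2 to compound 3 (0.22 log units; within the scatter). It exchanges one trifluoromethyl-bearing group for another and stays within the scatter. Among the measured compounds shown here, no measured step exchanges a trifluoromethyl-bearing group for a nitrile-bearing one, so the direct evidence is thin. The values do show that the group on this oxygen can matter in this assay, with compound 1 at 12800 nM and compound 3 at 52200 nM. A modest move toward a lower number is therefore the working expectation, held with wide uncertainty.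

The expected step is a 2.1-fold lower number from compound 3 to compound 4 (0.32 log units; beyond the scatter).

Compound 4 is estimated at 25000 nM, with an expected range of 9000 nM to 60000 nM.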

Compound 4, half-maximal inhibitory concentration: 42600 nM
Beside the measured number, compound 4's estimate is 1.7-fold (0.23 log units) below it; measured number inside the range.
By their numbers in this assay, from the lowest: compound 1; then compounds 2, 4 and 3 (each within the scatter of the next).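

In this assay, replacing either trifluoromethyl-bearing group with 4-cyanophenyl gives no separable change: a 1.2-fold lower number from compound 3 to compound 4 (0.09 log units; within the scatter) and a 1.3-fold higher number from compound 2 to compound 4 (0.13 log units; within the scatter). On these values, this place tolerates the exchange of a trifluoromethyl-bearing group for a nitrile-bearing one without a readable shift, even though the hydrogen-bond acceptor count and the heavy-atom count of the group both change. Among these compounds, the one new step beyond the scatter is a 3.3-fold higher number from compound 1 to compound 4 (0.52 log units; beyond the scatter), where a nitrile replaces the pentafluorosulfanyl group on an aromatic carbon, so the group carried on this ring can still move the number, and compound 1 is the compound that stands apart from compound 4. Nothing shown here gives a measured reason for either the flat steps or the larger one.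

Whether the separation of compound 1 from compound 4 is specific to the pentafluorosulfanyl group remains open, since the compounds shown do not include an unsubstituted phenyl, an amine or a carboxylic acid at this place. Also open, from the compounds shown here alone, is whether a longer chain on the oxygen would leave the number in the same range.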